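Chromone Thioamides and Dithiazoles: Removing a Chlorine

This account rests on a few compounds, and the source may have more. Where it says the series, first, only, none or still open, it means among the compounds named here.

Compound 1 `O=c1c(C(=S)Nc2ccccc2)coc2cc(Cl)ccc12` gives > 100000 nM in a functional assay on COLO 205 cells (Homo sapiens) for inhibition, read by sulforhodamine B assay, with a stated time of 48 h (on this read-out lower numbers stand for stronger inhibition and higher numbers for weaker inhibition), which is a limit of the assay rather than a number.
Compound 2 `O=c1c(C2N=C(c3ccccc3)SS2)coc2ccc(Cl)cc12` gives > 100000 nM in this assay, again a limit.
Compound 3 `O=c1c(C2N=C(c3ccccc3)SS2)coc2cc(Cl)c(Cl)cc12` gives > 100000 nM in this assay, also a limit.

All three measured compounds sit at the same limit, as the limit of > 100000 nM in this assay, at which 3 of the 3 values shown sit, shows. Compound 1 and compound 3 have different cores; the difference between the two cores is not broken down here. From compound 3 to compound 2 the change is hydrogen in place of chloro on an aromatic carbon, and its step that the two limits leave unreadable from compound 3 to compound 2 cannot be read, since both ends are limits.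

Compound 4 `O=c1c(C(=S)Nc2ccccc2)coc2ccccc12` has not yet been measured. Its change from compound 1 is hydrogen in place of chloro on an aromatic carbon. This is the same kind of change as from compound 3 to compound 2, but the surroundings differ: in compound 3 the leaving chloro sits ortho to a chloro group, while in compound 1 it does not.

With every measured value at the limit, no step size is readable, so the expectation for the step from compound 1 to compound 4 is essentially no change, a step that the limit leaves unreadable from compound 1 to compound 4. Compound 4 is expected to give 200000 nM, most likely again only as a limit, with a range from 50000 nM to 1000000 nM.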

Compound 4, half-maximal inhibitory concentration: 72600 nM
Compound 4: the middle estimate sits 2.8-fold (0.44 log units) above what was measured; the range from low to high includes it.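

In this assay, replacing chloro with hydrogen on an aromatic carbon gives an at least 1.3-fold lower number from compound 1 to compound 4 (0.13 log units; that floor lies within the scatter). Compound 1 is only a limit, so this figure is a floor: the real step may be larger, but the floor alone does not establish a gain from removing the chloro. The same change on the other core, from compound 3 to compound 2, cannot be read, so nothing here shows whether the change carries from one core to the other, and most of the data give no number to compare: the limit of > 100000 nM in this assay, at which 3 of the 4 values shown sit.

The compounds shown leave open whether a different group at the same place on the ring, such as an amine or a carboxylic acid, would shift the value of compound 4 in either direction. They also leave open whether any such replacement would lift the core of compound 2 to a value that can be read as a number.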